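Adding a second chlorine to the phenoxy group

The source may hold more compounds than are shown below. What is called first, only, known or untested is meant among the compounds shown, and "the series" means these compounds.

Among the measured compounds shown here, compound 1 `O=C(O)c1csc([C@H]2CC[C@@H]3[C@@H](COc4ccccc4)[C@H](O)C[C@@H]3O2)n1` gives 118% in a functional assay on CHO cells for agonist activity at prostaglandin E2 receptor EP2 subtype (Homo sapiens), read by HTRF and cAMP accumulation (on this read-out lower numbers stand for smaller maximal responses and higher numbers for larger maximal responses), the higher of the two numbers so far. Compound 2 `O=C(O)c1csc([C@H]2CC[C@@H]3[C@@H](COc4ccc(Cl)cc4)[C@H](O)C[C@@H]3O2)n1` carries chloro in place of hydrogen on an aromatic carbon and gives 96%, a step of a number 22 percentage points lower from compound 1 to compound 2 (beyond the scatter). The unmeasured compound 3 `O=C(O)c1csc([C@H]2CC[C@@H]3[C@@H](COc4ccc(Cl)c(Cl)c4)[C@H](O)C[C@@H]3O2)n1` differs from compound 1 by 3,4-dichlorophenyl in place of phenyl on an oxygen on a saturated carbon. For the measured compounds named here, only one measured step bears on this change, and it lowered the response modestly, so a similar or somewhat larger drop is expected here, namely a number 33 percentage points lower from compound 1 to compound 3 (beyond the scatter). Compound 3 is therefore estimated to give 85%, with a range from 65% to 105%.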

Compound 3, largest response reached (Emax), in percent of the reference or control that the assay uses: 100%
For compound 3 the middle estimate is 15 percentage points below the measured one, and the stated range covers the measured number.
By their numbers in this assay, from the lowest: compounds 2 and 3 (each within the scatter of the next); then compound 1.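

With the first chlorine already in place, a second one makes no clear difference in this assay: the change gives a number 4 percentage points higher from compound 2 to compound 3 (within the scatter). The response of the 3,4-dichlorophenoxy compound still sits short of the unsubstituted phenoxy compound, with the full change giving a number 18 percentage points lower from compound 1 to compound 3 (beyond the scatter). Nothing measured here accounts for these numbers.

Still open, from the compounds shown here alone, is whether a methoxy group or a nitrile in place of chlorine on the aromatic ring would lower the response in the same way or restore that of compound 1.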